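Adding a Methyl to the Pyridin-3-yl Amide

The source may hold more compounds than are shown below. What is called first, only, known or untested is meant among the compounds shown, and "the series" means these compounds.

In an in vitro ADME assay on microsomes from liver (Mus musculus) for pharmacokinetics, read by LC-MS, with a stated time of 10 min, tested at 1 uM (a lower number here means slower removal, a higher number faster removal of the compound), three compounds built on a shared core have been measured. Compound 1 `COc1ccc(NC(=O)[C@H]2CN(C)C[C@@H]2c2ccc(/C=C/C(=O)Nc3ccccc3N)cc2)cc1` gives 54 mL/min/kg, compound 2 `CN1C[C@H](C(=O)Nc2ccc(Br)cc2)[C@@H](c2ccc(/C=C/C(=O)Nc3ccccc3N)cc2)C1` gives 16 mL/min/kg and compound 3 `CN1C[C@H](C(=O)Nc2cccnc2)[C@@H](c2ccc(/C=C/C(=O)Nc3ccccc3N)cc2)C1` gives 41 mL/min/kg. Compound 3 stands level with compound 1, since the exchange of amide aryl groups gives a 1.3-fold lower number from compound 1 to compound 3 (0.12 log units; within the scatter), whereas the comparison with the bromo compound gives a 2.6-fold higher number from compound 2 to compound 3 (0.41 log units; beyond the scatter).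

Compound 4 `Cc1ccc(NC(=O)[C@H]2CN(C)C[C@@H]2c2ccc(/C=C/C(=O)Nc3ccccc3N)cc2)cn1` alters compound 3 at one place: methyl in place of hydrogen on an aromatic carbon. This is methyl in place of hydrogen on an aromatic carbon, next to the ring nitrogen and para to a large group. Going by the values given here, no measured step adds a methyl. The closest guide is the exchange of one aromatic substituent for another, bromo for methoxy, which gave a 3.4-fold lower number from compound 1 to compound 2 (0.53 log units; beyond the scatter), a modest step. With so little evidence on direction, only a small change is expected, and none beyond the scatter. The expected step is a 1.1-fold higher number from compound 3 to compound 4 (0.04 log units; within the scatter). For compound 4 the estimated value is 45 mL/min/kg, with an expected range from 22 mL/min/kg to 78 mL/min/kg.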

Compound 4, clearance: 57 mL/min/kg
The estimate for compound 4 lay 1.3-fold (0.10 log units) below the measured number; the measured number falls inside the stated range.
By their numbers in this assay, from the lowest: compound 2; then compounds 3, 1 and 4 (each within the scatter of the next).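

In this assay, methyl in place of hydrogen on an aromatic carbon, next to the ring nitrogen and para to a large group, leaves the number within the scatter (a 1.4-fold higher number from compound 3 to compound 4 (0.14 log units; within the scatter)), so this position tolerates the change without a readable shift. The 6-methylpyridin-3-yl amide also stands level with the 4-methoxyphenyl amide (a 1.1-fold higher number from compound 1 to compound 4 (0.02 log units; within the scatter)) but remains clearly apart from the 4-bromophenyl amide (a 3.6-fold higher number from compound 2 to compound 4 (0.55 log units; beyond the scatter)), which leaves compound 2 alone at the low end of the series. Nothing available explains these numbers. On these data alone, what remains open is whether trifluoromethyl or an amine at this same place would move the number beyond the scatter. As far as these compounds go, it is also open whether a methyl on another aromatic carbon of this ring would behave as this one does.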